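The source may hold more compounds than are shown below. What is called first, only, known or untested is meant among the compounds shown, and "the series" means these compounds.

Measured compounds:
compound 1 `Cc1ccc(C(=O)Nc2cc(-c3ccccc3)nn2-c2ccccc2)cc1` — 64 nM
compound 2 `O=C(Nc1cc(-c2ccccc2Cl)nn1-c1ccccc1)c1ccccc1` — 2290 nM
compound 3 `N#Cc1cccc(C(=O)Nc2cc(-c3ccccc3)nn2-c2ccccc2Br)c1` — 50 nM

In a functional assay on cells for positive allosteric modulation of metabotropic glutamate receptor 5 (Rattus norvegicus), read by calcium flux (on this read-out lower numbers stand for an effect already at smaller amounts and higher numbers for an effect only at larger amounts of compound), compound 1 gives 64 nM, the second highest of the three numbers. Compound 3 gives 50 nM, a value within the scatter of that of compound 1, so no order between the two is claimed. Compound 2 gives 2290 nM, a number far beyond the scatter above compound 1; compound 2 also differs from compound 1 in more than one place, so this gap is recorded without further reading.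

Compound 4 `O=C(Nc1cc(-c2ccccc2)nn1-c1ccccc1)c1ccncc1` has not yet been measured in this assay. It differs from compound 1 in one place: pyridin-4-yl in place of 4-methylphenyl on a carbonyl carbon. Going by the values given here, no measured pair isolates this change, so nothing among the three numbers fixes its size. A modest upward shift in this assay is expected, possibly no larger than the scatter. The expected step is a 2.8-fold higher number from compound 1 to compound 4 (0.45 log units; beyond the scatter). Compound 4 is estimated at 180 nM, with a range from 60 nM to 600 nM.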

Compound 4, half-maximal effective concentration: 2500 nM
Estimate against measurement, compound 4: 14-fold (1.14 log units) below; the whole stated range lies below it.
By their numbers in this assay, from the lowest: compounds 3 and 1 (each within the scatter of the next); then compounds 2 and 4 (each within the scatter of the next).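

In this assay, the group on the carbonyl carbon proves far from indifferent: pyridin-4-yl in place of 4-methylphenyl gives a large step (a 39-fold higher number from compound 1 to compound 4 (1.59 log units; beyond the scatter)), well beyond the scatter. Going by these compounds alone, this is the first pair that differs in one place, and so the first change whose size can be read directly. Nothing at hand explains the step.

The change removes the methyl and brings in a ring nitrogen together, so the data do not separate the two, and a methoxy group, an ethyl group or a saturated piperidine ring on the same carbonyl carbon remains an open case. Also open, going by these compounds, is whether the step keeps its size on a core carrying other groups, such as the bromine of compound 3.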